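Replacing the two-ring group on the shared core

This account rests on a few compounds, and the source may have more. Where it says the series, first, only, none or still open, it means among the compounds named here.

compound 1 `NC1CCC(Nc2nc(NCc3ccc(-c4ccco4)cc3)c3ncn(C4CCCC4)c3n2)CC1` - 85 nM
compound 2 `NC1CCC(Nc2nc(NCc3ccc(-c4ccsc4)nc3)c3ncn(C4CCCC4)c3n2)CC1` - 100 nM

Among the measured compounds shown here, in a functional assay on MCF7 cells (Homo sapiens) for inhibition, with a stated time of 72 h (a lower number here means a stronger inhibitor, a higher number a weaker inhibitor), compound 2 stands level with compound 1, the only other compound measured, and the step between them is a 1.2-fold higher number from compound 1 to compound 2 (0.07 log units; within the scatter). Compound 3 `NC1CCC(Nc2nc(NCc3cc(Cl)ccc3O)c3ncn(C4CCCC4)c3n2)CC1` keeps the shared core and changes one group: 5-chloro-2-hydroxyphenyl in place of 6-(thiophen-3-yl)pyridin-3-yl on a saturated chain carbon bound to a nitrogen on an aromatic ring. Thus 5-chloro-2-hydroxyphenyl stands in place of 6-(thiophen-3-yl)pyridin-3-yl on a saturated chain carbon bound to a nitrogen on an aromatic ring. For the measured compounds named here, the single measured step, a 1.2-fold higher number from compound 1 to compound 2 (0.07 log units; within the scatter), exchanged one two-ring group for another, so it offers only weak guidance for a group with one ring, and no measured compound carries such a group. A moderately higher number in this assay is expected, with low confidence. The estimated step is a 3.0-fold higher number from compound 2 to compound 3 (0.48 log units; beyond the scatter). For compound 3 the expected value is 300 nM, with an estimated range from 90 nM to 1000 nM.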

Compound 3, half-maximal inhibitory concentration: 430 nM
For compound 3 the middle estimate is 1.4-fold (0.16 log units) below the measured one; the range from low to high includes it.
By their numbers in this assay, from the lowest: compounds 1 and 2 (each within the scatter of the next); then compound 3.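

In this assay, among the compounds shown here, this is the first change on a saturated chain carbon bound to a nitrogen on an aromatic ring to move the number beyond the scatter: 5-chloro-2-hydroxyphenyl in place of 6-(thiophen-3-yl)pyridin-3-yl gives a 4.3-fold higher number from compound 2 to compound 3 (0.63 log units; beyond the scatter), and in place of 4-(furan-2-yl)phenyl it gives a 5.1-fold higher number from compound 1 to compound 3 (0.70 log units; beyond the scatter). The two two-ring groups could not be told apart, whereas the one-ring group gives a higher number than either, so this place does respond to the group it carries. Nothing available gives a reason for this difference.

Going by these compounds, the hydroxyl, the chlorine and the loss of the second ring all change together here, so which of them matters stays open. Also open, on these data alone, is how a plain phenyl, or a ring bearing an amine or a carboxylic acid, would stand at this place.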